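Chloro in place of fluoro on an aromatic carbon

The source may hold more compounds than are shown below. What is called first, only, known or untested is meant among the compounds shown, and "the series" means these compounds.

In an ADME assay on the whole organism (Rattus norvegicus, strain Han Wistar) for metabolic stability, at a dose of 1.2 umol/kg by the intravenous route (on this read-out lower numbers stand for a shorter-lived compound and higher numbers for a longer-lived compound), compound 1 (`CC(=O)N[C@@H]1CCC[C@H](C(=O)Nc2cc(-c3cnn4c3CCCC4)c(Cl)cn2)C1`) gives 0.25 h and compound 2 (`CC(=O)N[C@@H]1CCC[C@H](C(=O)Nc2cc(-c3cnn4c3CC(C)(C)C4)c(F)cn2)C1`) gives 0.18 h, so compound 2 stands within the scatter of compound 1. Compound 3 (`CC(=O)N[C@@H]1CCC[C@H](C(=O)Nc2cc(-c3cnn4c3CC(C)(C)C4)c(Cl)cn2)C1`) follows from compound 2 with chloro in place of fluoro on an aromatic carbon, ortho to a large group: chloro in place of fluoro on an aromatic carbon. Within the data shown here, no measured pair shows this change alone, so no step beyond the scatter is expected in this assay, in either direction. The expected change is a 1.2-fold higher number from compound 2 to compound 3 (0.09 log units; within the scatter). For compound 3 the estimated value is 0.22 h, with an expected range from 0.12 h to 0.4 h.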

Compound 3, half-life: 0.18 h
Estimate against measurement, compound 3: 1.2-fold (0.09 log units) above; the range from low to high includes it.
By their numbers in this assay, from the lowest: compounds 2, 3 and 1 (each within the scatter of the next).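

In this assay, the exchange of fluoro for chloro on this aromatic carbon, ortho to a large group, now has a measured pair, which shows no change at the digits printed from compound 2 to compound 3 (within the scatter). With chloro held constant, swapping the group on the other aromatic carbon gives a 1.4-fold lower number from compound 1 to compound 3 (0.14 log units; within the scatter). Nothing measured here offers an explanation for either result. From the compounds shown here alone, whether a nitrile or a trifluoromethyl on the chloro-bearing carbon would move the half-life beyond the scatter remains open. So does whether fluoro and chloro would also match on the core of compound 1.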